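This account rests on a few compounds, and the source may have more. Where it says the series, first, only, none or still open, it means among the compounds named here.

Compound 2 `CC(=O)Nc1ccc(Cc2noc(CCC(=O)Nc3ccc(F)cc3)n2)cc1` gives 64.4% in a functional assay on the whole organism (strain C57BL/6) for inhibition, with Mus musculus as the target, read by paw edema, with stated times of 1 h and 4 h, at a dose of 100 mg/kg by the oral route (a lower number here means less inhibition, a higher number more inhibition at the dose given (going by the name of the read-out)), the higher of the two numbers in hand. Among the measured compounds shown here, its one measured neighbour is compound 1 `COc1ccc(NC(=O)CCc2nc(Cc3ccc(NC(C)=O)cc3)no2)cc1`, and compound 1 gives 49.3%, so that the step of a number 15.1 percentage points higher from compound 1 to compound 2 (beyond the scatter) is the only change measured so far. Compound 3 `CC(=O)Nc1ccc(Cc2noc(CCC(=O)Nc3ccc(F)cc3F)n2)cc1` differs from compound 2 by fluoro in place of hydrogen on an aromatic carbon. For the measured compounds named here, no measured step adds a fluoro beside one already present, and the fluoro-for-methoxy step is at best a loose guide. The step of a number 0.6 percentage points higher from compound 2 to compound 3 (within the scatter) is expected to stay within the scatter. Compound 3 is therefore estimated at 65%, between 50% and 80%.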

Compound 3, a percentage reported as inhibition, in the whole organism at one dose (the size of the read-out at that dose, not a potency): 52.1%
Compound 3: the middle estimate sits 12.9 percentage points above what was measured, and the stated range covers the measured number.
By their numbers in this assay, from the lowest: compounds 1 and 3 (each within the scatter of the next); then compound 2.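

In this assay, a second fluoro, ortho to a large group and meta to the first fluoro, gives a number 12.3 percentage points lower from compound 2 to compound 3 (beyond the scatter), so the added fluoro lowers the number here rather than extending the gain seen with the 4-fluorophenyl group. Set against the 4-methoxyphenyl group, the 2,4-difluorophenyl group gives a number 2.8 percentage points higher from compound 1 to compound 3 (within the scatter), and the two cannot be told apart. No evidence on hand bears on this result.

From the compounds shown here alone, whether a chloro or a methyl group at this same place would also lower the number stays open. So does whether the 2-fluorophenyl group alone would match the 2,4-difluorophenyl group.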